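The source may report more compounds than this note shows. Statements on the series, on what has been measured and on what is new or still open speak of the compounds shown alone.

Series notes. Compound 1 `O=C(Cn1cnc([N+](=O)[O-])n1)N1CCN(c2ccc(Cl)cc2)CC1` was run in an ADME assay on L6 cells (Rattus norvegicus) for cytotoxicity; on this read-out higher numbers stand for weaker inhibition and lower numbers for stronger inhibition; in it compound 1 returns only a limit, > 285000 nM. That limit of > 285000 nM in this assay, at which 1 of the 2 values shown sits, is all that is known of compound 1 in this assay. Compound 2 `Cc1ccc(N2CCN(CC(=O)N3CCN(c4ccc(C)cc4)CC3)CC2)cc1` gives 213000 nM in this assay. Compound 3 `O=C(Cn1cnc([N+](=O)[O-])n1)N1CCN(c2ccccn2)CC1` awaits measurement and differs from compound 1 by pyridin-2-yl in place of 4-chlorophenyl on an amine nitrogen in a ring. Among the compounds with values here, no measured step exists between measured compounds here. The step that the limit leaves unreadable from compound 1 to compound 3 is expected to be none beyond the scatter. Compound 3 is expected at 300000 nM in this assay, within 140000 nM to 650000 nM, and most likely returns a limit again.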

Compound 3, half-maximal inhibitory concentration: 173000 nM
Estimate against measurement, compound 3: 1.7-fold (0.24 log units) above, within the range that was stated.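

With pyridin-2-yl on an amine nitrogen in a ring, compound 3 gives a full value of 173000 nM in this assay, so this position yields a readable number on the core of compound 1. The change gives an at least 1.6-fold lower number from compound 1 to compound 3 (0.21 log units; that floor lies within the scatter), so no shift beyond the scatter is established. Compound 1 stands at a limit, so only a floor of the step can be read: the limit of > 285000 nM in this assay, at which 1 of the 3 values shown sits.

Still open, as far as these compounds go, is whether a non-aromatic group at this position, such as an amine or a longer chain, moves the number beyond the scatter.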